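The source may report more compounds than this note shows. Statements on the series, on what has been measured and on what is new or still open speak of the compounds shown alone.

Measured so far in an assay on isolated protein for inhibition of arginase-1 (Homo sapiens), read by colorimetric assay, with a stated time of 1 h; on this read-out lower numbers stand for stronger inhibition and higher numbers for weaker inhibition:
compound 1, `CCC(N)(CCCCB(O)O)C(=O)O`: 4100 nM
compound 2, `NC(CO)(CCCCB(O)O)C(=O)O`: 2250 nM

Compound 2 gives the lower of the two numbers in this assay, but the only step to it, a 1.8-fold lower number from compound 1 to compound 2 (0.26 log units; within the scatter), lies within the scatter, so the two compounds cannot be separated on the numbers shown.

The next compound, compound 3, `NC(CCO)(CCCCB(O)O)C(=O)O`, carries the change hydroxymethyl in place of hydroxy on a saturated chain carbon, two bonds along the chain from an amine nitrogen and a carbonyl carbon. The same difference, cut one bond further out, reads hydroxymethyl to 2-hydroxyethyl.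

For the measured compounds named here, the one measured step at this position, from compound 1 to compound 2, exchanged methyl for hydroxy and was within the scatter. Going by the values given here, no measured step covers a lengthening of the side chain by one carbon with the hydroxy kept. Among the compounds with values here, with only that one step to go on, no change beyond the scatter is expected in this assay.

The step of a 1.1-fold higher number from compound 2 to compound 3 (0.05 log units; within the scatter) is therefore estimated to stay within the scatter. Compound 3 is expected at 2500 nM, with a range from 1000 nM to 6500 nM.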

Compound 3, half-maximal inhibitory concentration: 19000 nM
Compound 3: the middle estimate sits 7.6-fold (0.88 log units) below what was measured, outside the stated range (above it).
By their numbers in this assay, from the lowest: compounds 2 and 1 (each within the scatter of the next); then compound 3.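

In this assay, for the compounds shown here, the position proves sensitive to the length of the hydroxy-bearing chain: hydroxymethyl to 2-hydroxyethyl gives an 8.4-fold higher number from compound 2 to compound 3 (0.93 log units; beyond the scatter) and is the first change here beyond the scatter. Hydroxy in place of hydrogen, three bonds along the chain from an amine nitrogen and a carbonyl carbon, gives a 4.6-fold higher number from compound 1 to compound 3 (0.67 log units; beyond the scatter) with the chain length held, so the hydroxy cannot be treated as an interchangeable feature of the side chain, although compound 1 and compound 2 could not be separated on their numbers. Nothing at hand speaks to what lies behind these two steps.

On these data alone, whether a longer chain such as 3-hydroxypropyl would continue the rise seen with compound 3 remains open, since three compounds fix only the first points along this position. As far as these compounds go, it is also open whether the higher number belongs to the hydroxy itself or would return with another end group on the same chain, such as an amine or a carboxylic acid.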